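From Pyridin-3-yl to Pyrrolidin-3-yl on the Carbonyl Carbon

The source may hold more compounds than are shown below. What is called first, only, known or untested is meant among the compounds shown, and "the series" means these compounds.

The three measured compounds, each read in an assay on U2OS cells for inhibition of secreted frizzled-related protein 1 (Homo sapiens), read by a luciferase reporter, with a stated time of 18 h; a higher number here means that more compound is needed for the effect, a lower number that less compound is needed:

Compound 1 `O=C(c1cccnc1)N1CCC(NS(=O)(=O)c2cc(S(=O)(=O)c3ccccc3)ccc2C(F)(F)F)CC1` gives 120 nM.
Compound 2 `CN(C)c1ccc(C(=O)N2CCC(NS(=O)(=O)c3cc(S(=O)(=O)c4ccccc4)ccc3C(F)(F)F)CC2)cn1` gives 70 nM.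
Compound 3 `O=C(O)CCCC(=O)N1CCC(NS(=O)(=O)c2cc(S(=O)(=O)c3ccccc3)ccc2C(F)(F)F)CC1` gives 570 nM.

Compound 1 stands second highest of these three numbers. Its nearest neighbour is compound 2: the step of a 1.7-fold lower number from compound 1 to compound 2 (0.23 log units; within the scatter) lies within the scatter, so the two cannot be ordered. Its furthest is compound 3: the step of a 4.8-fold higher number from compound 1 to compound 3 (0.68 log units; beyond the scatter) lies beyond the scatter and is modest in size, and the related step of an 8.1-fold higher number from compound 2 to compound 3 (0.91 log units; beyond the scatter) points the same way.

Compound 4 `O=C([C@H]1CCNC1)N1CCC(NS(=O)(=O)c2cc(S(=O)(=O)c3ccccc3)ccc2C(F)(F)F)CC1` differs from compound 1 in one place: pyrrolidin-3-yl in place of pyridin-3-yl on a carbonyl carbon. Among the compounds with values here, the step that bears on this change is the one from compound 1 to compound 3, where the pyridin-3-yl on the same carbonyl carbon was likewise replaced by a non-aromatic group and the number rose modestly. On that basis a modest rise beyond the scatter is expected for compound 4, expressed as a 2.1-fold higher number from compound 1 to compound 4 (0.32 log units; beyond the scatter). Compound 4 is therefore estimated at 250 nM, with a range from 100 nM to 700 nM.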

Compound 4, half-maximal effective concentration: 700 nM
Beside the measured number, compound 4's estimate is 2.8-fold (0.45 log units) below it; the range from low to high includes it.
By their numbers in this assay, from the lowest: compounds 2 and 1 (each within the scatter of the next); then compounds 3 and 4 (each within the scatter of the next).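

In this assay, a non-aromatic ring on this carbonyl carbon gives a 5.8-fold higher number from compound 1 to compound 4 (0.77 log units; beyond the scatter), and measured against the 6-(dimethylamino)pyridin-3-yl group the change gives a 10-fold higher number from compound 2 to compound 4 (1.00 log units; beyond the scatter). The earlier compounds had shown a higher number only with the open 3-carboxypropyl chain; the pyrrolidin-3-yl ring now sits on the same high side, and a 1.2-fold higher number from compound 3 to compound 4 (0.09 log units; within the scatter) means that these two groups cannot be ordered. No measurement shown accounts for the higher number with either group.

The compounds shown leave open whether the rise goes with losing the aromatic ring or with the added hydrogen-bond donor, a distinction a cyclohexyl group on this carbonyl carbon would help to draw. Also open, as far as these compounds go, is what the pyrrolidin-3-yl group of opposite configuration at its stereocentre would give.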